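The compounds below may be only part of what the source reports. "The series", "measured", "known", "first", "only" and "open" are said of these compounds alone.

Measured compounds:
compound 1 `Oc1cccc(-c2cc(-c3cccc(C(F)(F)F)c3)cc(-c3cccc(O)c3)n2)c1`: in a functional assay on DU-145 cells (Homo sapiens) for inhibition (on this read-out lower numbers stand for stronger inhibition and higher numbers for weaker inhibition), compound 1 gives > 50000 nM, a limit of the assay.
compound 2 `Oc1cccc(-c2cc(-c3ccc(C(F)(F)F)cc3)cc(-c3cccc(O)c3)n2)c1`: in this assay compound 2 gives 33500 nM.
compound 3 `Oc1ccc(-c2cc(-c3cccc(C(F)(F)F)c3)cc(-c3ccc(O)cc3)n2)cc1`: in this assay compound 3 gives > 50000 nM, a limit of the assay.

The change 4-(trifluoromethyl)phenyl in place of 3-(trifluoromethyl)phenyl on an aromatic carbon gave an at least 1.4-fold lower number from compound 1 to compound 2 (0.17 log units; that floor lies within the scatter). The same kind of change turns compound 3 into compound 4 `Oc1ccc(-c2cc(-c3ccc(C(F)(F)F)cc3)cc(-c3ccc(O)cc3)n2)cc1`, namely (4-(trifluoromethyl)phenyl in place of 3-(trifluoromethyl)phenyl on an aromatic carbon), here meta to two 4-hydroxyphenyl groups rather than meta to two 3-hydroxyphenyl groups; the difference between the cores of compound 1 and compound 3 is not broken down here. Compound 3 sits at the limit of > 50000 nM in this assay, at which 2 of the 3 values shown sit, which is the same limit as that of compound 1. For compound 4 a step of about an at least 1.2-fold lower number from compound 3 to compound 4 (0.09 log units; that floor lies within the scatter) in this assay is expected, because an at least 1.4-fold lower number from compound 1 to compound 2 (0.17 log units; that floor lies within the scatter) stayed within the scatter. Compound 4 is therefore estimated near 40000 nM, between 20000 nM and 100000 nM, with a real chance that the assay again reports only a limit.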

Compound 4, half-maximal inhibitory concentration: > 50000 nM
Compound 4: a limit, no number; the forecaster's own chance of this, stated with the estimate: 60%; middle value at least 1.2-fold (0.09 log units) away from the limit.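

For the compounds shown here, compound 4 stops at the same limit of the assay as compound 3, so no step between them can be read: the limit of > 50000 nM in this assay, at which 3 of the 4 values shown sit. Still open, from the compounds shown here alone, is whether 4-(trifluoromethyl)phenyl in place of 3-(trifluoromethyl)phenyl changes inhibition at all on the core of compound 3.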